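Trading a Methoxy for Hydrogen in a Paw-Edema Series

The compounds below may be only part of what the source reports. "The series", "measured", "known", "first", "only" and "open" are said of these compounds alone.

compound 1, `O/N=C(/CSc1nnc(-c2ccccc2)n1-c1ccccc1)c1ccccc1`: 63%
compound 2, `CCn1c(SC/C(=N/O)c2ccccc2)nnc1-c1ccc(OC)cc1`: 72%

In a functional assay on the whole organism (strain albino) for inhibition, with Rattus norvegicus as the target, read by paw edema, with a stated time of 2 h, at a dose of 0.28 mmol/kg by the oral route (a lower number here means less inhibition, a higher number more inhibition at the dose given (going by the name of the read-out)), compound 2 gives 72%, the highest of the two numbers, while compound 1 at 63% sits within the usual scatter of it, so the two cannot be ranked. Compound 3 `CCn1c(SC/C(=N/O)c2ccccc2)nnc1-c1ccccc1` has not yet been measured; it differs from compound 2 by hydrogen in place of methoxy on an aromatic carbon. Among the compounds with values here, no step between two measured compounds is available to calibrate this change, so the step of a number 7 percentage points lower from compound 2 to compound 3 (within the scatter) is expected to stay within the scatter, in no particular direction. Compound 3 is estimated at 65%, with a range from 50% to 80%.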

Compound 3, a percentage reported as inhibition, in the whole organism at one dose (the size of the read-out at that dose, not a potency): 69%
For compound 3 the middle estimate is 4 percentage points below the measured one; low and high end bracket the measured number.
By their numbers in this assay, from the lowest: compounds 1, 3 and 2 (each within the scatter of the next).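

In this assay, hydrogen in place of methoxy on the aromatic carbon gives a number 3 percentage points lower from compound 2 to compound 3 (within the scatter), and ethyl in place of phenyl on the aromatic nitrogen gives a number 6 percentage points higher from compound 1 to compound 3 (within the scatter). Neither change shifts the inhibition beyond the usual scatter, so at this dose the read-out does not separate the groups compared at either place. Nothing measured here speaks to the reason for this. Going by these compounds, whether an amine or a carboxylic acid on that aromatic carbon would shift the inhibition remains open. So does the effect of a longer chain on the nitrogen.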